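From an Unmeasured Compound to a Brominated Sulfanyl Relative

The source may hold more compounds than are shown below. What is called first, only, known or untested is meant among the compounds shown, and "the series" means these compounds.

Compound 1 `O=C(NC(=O)c1ccccc1)Nc1ccc(Sc2ncccn2)cc1`: "not determined" (no result reported)
Compound 2 `O=C(NC(=S)Nc1ccc(Oc2ncccn2)cc1)c1ccccc1`: "not determined" (no result reported)
Compound 3 `O=C(NC(=O)c1ccccc1)Nc1ccc(Sc2ncc(Br)cn2)cc1`: > 10000 nM

The test here is a functional assay on PANC-1 cells (Homo sapiens) for cytotoxicity, read by MTT assay; on this read-out lower numbers stand for stronger inhibition and higher numbers for weaker inhibition. Compound 2 has no number in this test, so its place on the scale is open. Only compound 3 carries a figure, and that figure is a limit, not a measured number: > 10000 nM.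

Compound 4 `O=C(NC(=S)Nc1ccc(Sc2ncc(Br)cn2)cc1)c1ccccc1` has not yet been measured. The change to follow is (5-bromopyrimidin-2-yl)sulfanyl in place of (pyrimidin-2-yl)oxy on an aromatic carbon, para to a large group.

Going by the values given here, no measured step in this assay shows what such a change does, and with no number for compound 2 the step itself cannot be sized. The working expectation is therefore no step beyond the usual scatter in either direction, with weak inhibition and a fair chance that only a limit is reported. For compound 4 the estimated value is 12000 nM, with an expected range from 3000 nM to 40000 nM.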

Compound 4, half-maximal inhibitory concentration: 9500 nM
The estimate for compound 4 lay 1.3-fold (0.10 log units) above the measured number; low and high end bracket the measured number.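

Compound 2 has no number in this assay, and compound 4 gives 9500 nM, so no step can be read between them. From the compounds shown here alone, what stays open is what (5-bromopyrimidin-2-yl)sulfanyl in place of (pyrimidin-2-yl)oxy does on its own, with readings here meeting a limit of the test: the limit of > 10000 nM in this assay, at which 1 of the 4 values shown sits.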